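A Carbonyl Group Replaces the Propylsulfonyl on the Anilide Nitrogen

A few compounds are considered here, and "the series" means these few. Any claim that something is new, unique, unknown or untested is made for them only; others in the source may bear on it.

Compound 2 `CCCS(=O)(=O)Nc1ccc(-c2cc(=O)c3c(O)cc(OC)c(OC(C)C)c3o2)cc1` gives the highest of the three numbers in a functional assay on DU-145 cells (Homo sapiens) for antiproliferative activity, read by MTT assay, with a stated time of 3 days (a higher number here means a weaker inhibitor, a lower number a stronger inhibitor), at 76900 nM. Compound 1 `COc1cc(O)c2c(=O)cc(-c3ccc(NS(C)(=O)=O)cc3)oc2c1OC(C)C` gives 19100 nM and compound 3 `C=CC(=O)Nc1ccc(-c2cc(=O)c3c(O)cc(OC)c(OC(C)C)c3o2)cc1` gives 14700 nM. Compound 4 `COc1cc(O)c2c(=O)cc(-c3ccc(NC(=O)N4CCN(C)CC4)cc3)oc2c1OC(C)C` differs from compound 2 by (4-methylpiperazin-1-yl)carbonyl in place of propylsulfonyl on a nitrogen on an aromatic ring. Among the measured compounds shown here, two measured steps bear on this change. The step of a 4.0-fold higher number from compound 1 to compound 2 (0.60 log units; beyond the scatter) shows that lengthening the chain on the sulfonyl sulfur weakened inhibition. The step of a 5.2-fold lower number from compound 2 to compound 3 (0.72 log units; beyond the scatter) shows that exchanging the propylsulfonyl for a carbonyl-bearing group strengthened it. Given the step of a 5.2-fold lower number from compound 2 to compound 3 (0.72 log units; beyond the scatter), a lower number of similar size is expected for compound 4, namely a 3.8-fold lower number from compound 2 to compound 4 (0.58 log units; beyond the scatter). Compound 4 is therefore estimated at 20000 nM, within a range from 6000 nM to 60000 nM.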

Compound 4, half-maximal inhibitory concentration: 12500 nM
The estimate for compound 4 lay 1.6-fold (0.20 log units) above the measured number; the measured number falls inside the stated range.
By their numbers in this assay, from the lowest: compounds 4, 3 and 1 (each within the scatter of the next); then compound 2.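

Replacing propylsulfonyl on the nitrogen with (4-methylpiperazin-1-yl)carbonyl gives a 6.2-fold lower number from compound 2 to compound 4 (0.79 log units; beyond the scatter) in this assay, so a second carbonyl-bearing group, this one with a ring, also parts from propylsulfonyl. Yet a 1.2-fold lower number from compound 3 to compound 4 (0.07 log units; within the scatter) and a 1.5-fold lower number from compound 1 to compound 4 (0.18 log units; within the scatter) both stay within the scatter, so among these four compounds only propylsulfonyl stands apart. No measurement here accounts for this result. Still open, as far as these compounds go, is whether a longer chain on the carbonyl carbon, or a carboxylic acid in place of the 4-methylpiperazin-1-yl, would stay level with compound 4 or fall toward compound 2.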